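The source may report more compounds than this note shows. Statements on the series, on what has been measured and on what is new or still open speak of the compounds shown alone.

Two members of the series have numbers in a functional assay on MCF7 cells (Homo sapiens) for antiproliferative activity, read by sulforhodamine B assay, with a stated time of 48 h; a higher number here means a weaker inhibitor of growth, a lower number a stronger inhibitor of growth. Compound 1 `CCCCc1ccc(-c2cc(N3CCC(CNS(N)(=O)=O)CC3)ncn2)cc1` gives 21800 nM. Compound 2 `CCCCc1ccc(-c2cc(N3CCC(CCNS(N)(=O)=O)CC3)ncn2)cc1`, which carries (sulfamoylamino)methyl in place of sulfamoylamino on a saturated chain carbon bound to a saturated ring carbon, gives 11300 nM. The step of a 1.9-fold lower number from compound 1 to compound 2 (0.29 log units; within the scatter) lies within the scatter, so the two compounds cannot be ordered; compound 2 simply holds the lower of the two numbers shown.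

Compound 3 `COC(=O)c1ccc(-c2cc(N3CCC(CCNS(N)(=O)=O)CC3)ncn2)cc1` has not been measured. It differs from compound 2 by methoxycarbonyl in place of butyl on an aromatic carbon, placed on the six-membered aromatic ring of carbon only, para to a large group. Within the data shown here, no measured step touches this part of the molecule: the only step in hand alters the chain on the saturated ring and is itself within the scatter. Among the measured compounds shown here, no measured step therefore bears on the change to compound 3, and no direction can be drawn from the series. The number for compound 3 is expected near that of compound 2, with a step of a 1.3-fold higher number from compound 2 to compound 3 (0.12 log units; within the scatter) that need not exceed the scatter. Compound 3 is estimated at 15000 nM in this assay, with a range from 3500 nM to 60000 nM.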

Compound 3, concentration for 50% growth inhibition: 17600 nM
For compound 3 the middle estimate is 1.2-fold (0.07 log units) below the measured one; the range from low to high includes it.
By their numbers in this assay, from the lowest: compounds 2, 3 and 1 (each within the scatter of the next).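

Among these compounds, this is the first reading on the aromatic carbon para to a large group: methoxycarbonyl in place of butyl gives a 1.6-fold higher number from compound 2 to compound 3 (0.19 log units; within the scatter) in this assay and so no readable shift in growth inhibition. At this position, exchanging butyl for methoxycarbonyl keeps the count of four heavy atoms but replaces an all-carbon chain with a group carrying two oxygens and two hydrogen-bond acceptors, and the number stays within the scatter of that of compound 2. Nothing available explains this outcome or links it to any measured property of either group.

The three compounds shown all lie within the scatter of their neighbours in the ordering, so it remains open whether a carboxylic acid, an amine or a longer alkyl chain at this position would move the number beyond the scatter. From the compounds shown here alone, it is also open whether methoxycarbonyl would give the same result on the shorter side chain of compound 1, where the sulfamoylamino group sits one carbon closer to the saturated ring.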